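Removing the para-methyl from compound 2: what to expect

The source may hold more compounds than are shown below. What is called first, only, known or untested is meant among the compounds shown, and "the series" means these compounds.

Compound 2 `C/C(=N\Nc1nc(-c2ccc(C)cc2)cs1)c1cc2ccccc2o1` is the stronger of the two measured compounds in a functional assay on MCF7 cells (Homo sapiens) for antiproliferative activity; on this read-out lower numbers stand for stronger inhibition and higher numbers for weaker inhibition: in this assay compound 2 gives 11100 nM, whereas compound 1 `C/C(=N\Nc1nc(-c2ccc(Br)cc2)cs1)c1cc2ccccc2o1` gives 33200 nM. For the measured compounds named here, the only measured step, a 3.0-fold lower number from compound 1 to compound 2 (0.48 log units; beyond the scatter), arises from methyl in place of bromo on an aromatic carbon. Compound 3 `C/C(=N\Nc1nc(-c2ccccc2)cs1)c1cc2ccccc2o1` is not yet measured; it differs from compound 2 by hydrogen in place of methyl on an aromatic carbon, so the 4-methylphenyl becomes a plain phenyl. Going by the values given here, no measured step tells how removing this methyl plays out, and the single bromo-to-methyl step does not speak to it directly. The expectation is therefore a step of about a 1.4-fold higher number from compound 2 to compound 3 (0.13 log units; within the scatter) in this assay, in either direction, with wide uncertainty. Compound 3 is thus expected to give roughly 15000 nM in this assay, within a range of 5000 nM to 45000 nM.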

Compound 3, half-maximal inhibitory concentration: 8490 nM
For compound 3 the middle estimate is 1.8-fold (0.25 log units) above the measured one; the measured number falls inside the stated range.
By their numbers in this assay, from the lowest: compounds 3 and 2 (each within the scatter of the next); then compound 1.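

In this assay, taking the methyl off the 4-methylphenyl gives a 1.3-fold lower number from compound 2 to compound 3 (0.12 log units; within the scatter) and so leaves no measurable difference between methyl and hydrogen at this position, para to a large group. Hydrogen in place of bromo gives a 3.9-fold lower number from compound 1 to compound 3 (0.59 log units; beyond the scatter) and matches the earlier step from bromo to methyl, so bromo now stands apart from both methyl and hydrogen, whereas the first pair alone could not show whether methyl had helped or bromo had hurt. Nothing available bears on what lies behind this difference.

Going by these compounds, whether chloro or fluoro would stay with hydrogen and methyl or fall with bromo remains open. So does the fate of a methoxy, an amine or a carboxylic acid at this position.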